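The compounds below may be only part of what the source reports. "The series", "measured", "known", "first", "only" and "open" are said of these compounds alone.

Compound 2, `CC(C)=CCC1Cc2c(OC(=O)Nc3cccc(F)c3)cc(=O)n(CCCO)c2CC1(C)C`, stands highest of the two numbers measured in a functional assay on PANC-1 cells (Homo sapiens) for inhibition, read by MTT assay, with a stated time of 24 h, tested at 10 uM (a higher number here means more inhibition at the concentration tested (going by the name of the read-out), a lower number less inhibition), where compound 2 gives 66.1%. The nearest value is that of compound 1, `CC(C)=CCC1Cc2c(OCCCOc3ccc(Cl)cc3)cc(=O)n(CCCO)c2CC1(C)C`, which in this assay gives 22.7%; the step between them, a number 43.4 percentage points higher from compound 1 to compound 2 (beyond the scatter), came with the (3-fluorophenyl)carbamoyl group replacing the 3-(4-chlorophenoxy)propyl group on the ring oxygen. Compound 3, `CC(C)=CCC1Cc2c(OC(=O)Nc3ccc(F)c(F)c3)cc(=O)n(CCCO)c2CC1(C)C`, differs from compound 2 by fluoro in place of hydrogen on an aromatic carbon. Among the measured compounds shown here, the single measured step concerns the exchange of the whole group on the oxygen, not the addition of a fluoro to the phenyl ring, so no measured step bears directly on this change. The expectation for compound 3 is therefore a step in this assay no larger than the scatter, a number 0.1 percentage points lower from compound 2 to compound 3 (within the scatter). Compound 3 is thus estimated at 66%, with a range from 48% to 80%.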

Compound 3, a percentage reported as inhibition, at one concentration (the size of the read-out at that concentration, not a potency): 76.7%
Estimate against measurement, compound 3: 10.7 percentage points below; the measured number falls inside the stated range.
By their numbers in this assay, from the lowest: compound 1; then compound 2; then compound 3.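

On the phenyl ring of the carbamoyl group, fluoro in place of hydrogen, on an aromatic carbon ortho to a fluoro group and para to a large group, is not a silent change in this assay: the move to (3,4-difluorophenyl)carbamoyl gives a number 10.6 percentage points higher from compound 2 to compound 3 (beyond the scatter). The earlier step replaced the whole group on the oxygen, whereas this one shows that a single added fluoro on the phenyl ring also shifts the reading, and the full exchange now amounts to a number 54 percentage points higher from compound 1 to compound 3 (beyond the scatter). Nothing available here explains this step.

Going by these compounds, what a chloro or a methoxy group would give at the same place on the ring remains open. A reading at one concentration also leaves open how these compounds compare in potency.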